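Benzoxazole Sulfonamides: Low Cytotoxicity and an Unmeasured Analogue

This account rests on a few compounds, and the source may have more. Where it says the series, first, only, none or still open, it means among the compounds named here.

Measured compounds:
compound 1 `O=S(=O)(Nc1ccc(-c2nc3ccccc3o2)cc1)c1ccc(F)c(C(F)(F)F)c1`, 82000 nM;
compound 2 `C=Cc1ccc(S(=O)(=O)Nc2ccc(-c3nc4ccccc4o3)cc2)cc1`, > 100000 nM;
compound 3 `O=[N+]([O-])c1cc(S(=O)(=O)Nc2ccc3oc(-c4ccccc4)nc3c2)ccc1Cl`, 90000 nM.

In an ADME assay on HEK293 cells (Homo sapiens) for cytotoxicity, read by resazurin assay, with a stated time of 48 h (on this read-out lower numbers stand for higher toxicity in this test and higher numbers for lower toxicity in this test), compound 1 gives 82000 nM and compound 3 gives 90000 nM. For compound 2 the result is not a number but a limit of this assay, > 100000 nM, so compound 2 stands at the limit of > 100000 nM in this assay, at which 1 of the 3 values shown sits. Compound 4 `Cc1cccc(S(=O)(=O)Nc2ccc(-c3nc4ccccc4o3)cc2)c1` has not yet been tested; it differs from compound 2 by 3-methylphenyl in place of 4-vinylphenyl on a sulfonyl sulfur. For the measured compounds named here, no measured pair with a single change is available, so the expected step from compound 2 to compound 4 is an at least 1.1-fold lower number from compound 2 to compound 4 (0.04 log units; that floor lies within the scatter), no larger than the scatter and in no particular direction. Compound 4 is therefore expected to give about 90000 nM, between 45000 nM and 180000 nM.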

Compound 4, half-maximal cytotoxic concentration: > 100000 nM
Compound 4: no number, only a limit (the forecaster's own chance of this, stated with the estimate: 40%); at least 1.1-fold (0.04 log units) between middle value and limit.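

In this assay compound 2 and compound 4 each give only a limit, not a number, so the step between them cannot be read: the limit of > 100000 nM in this assay, at which 2 of the 4 values shown sit. As far as these compounds go, whether 3-methylphenyl in place of 4-vinylphenyl on a sulfonyl sulfur changes the read-out at all stays open.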